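From 4-fluorophenyl to 3,4-dichlorophenyl on the shared core

The source may report more compounds than this note shows. Statements on the series, on what has been measured and on what is new or still open speak of the compounds shown alone.

In an ADME assay on H9c2 cells (Rattus norvegicus) for cytotoxicity, read by resazurin assay, with a stated time of 72 h (on this read-out higher numbers stand for lower toxicity in this test and lower numbers for higher toxicity in this test), compound 1 (`C/C(=N\Nc1nc(-c2ccncc2)cs1)c1ccc(Cl)c(Cl)c1`) gives 41900 nM. Compound 2 (`C/C(=N\Nc1nc(-c2ccc(F)cc2)cs1)c1ccc(Cl)c(Cl)c1`) gives > 50000 nM, which is a limit of the assay and not a number. Compound 2 therefore has no exact place on the scale. Compound 3 (`C/C(=N\Nc1nc(-c2ccc(Cl)c(Cl)c2)cs1)c1ccc(Cl)c(Cl)c1`) carries 3,4-dichlorophenyl in place of 4-fluorophenyl on an aromatic carbon. Going by the values given here, the one measured step at this place is an at least 1.1-fold higher number from compound 1 to compound 2 (0.07 log units; that floor lies within the scatter). It gives only a floor and involves a different group, so it offers weak guidance on size and direction. On that thin basis, only a modest move towards a lower number is expected in this assay, and another result at the limit remains possible. The expected step is an at least 1.2-fold lower number from compound 2 to compound 3 (0.09 log units; that floor lies within the scatter). Compound 3 is estimated at 40000 nM, with an expected range of 15000 nM to 60000 nM.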

Compound 3, half-maximal cytotoxic concentration: > 50000 nM
Compound 3 gave a limit, no number; the forecaster's own chance of this, stated with the estimate: 45%; middle value at least 1.2-fold (0.09 log units) away from the limit.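

In this assay compound 3 gives > 50000 nM, which is a limit of the assay and not a number. This shows that a second substituted phenyl group at this position, 3,4-dichlorophenyl, also ends at the limit, while compound 1, with pyridin-4-yl, is the one compound shown with an exact number; set against that group, the change gives an at least 1.1-fold higher number from compound 1 to compound 3 (0.07 log units; that floor lies within the scatter). The step between compound 2 and compound 3 cannot be read because both results are the same limit: the limit of > 50000 nM in this assay, at which 2 of the 3 values shown sit.

From the compounds shown here alone, how far compound 2 and compound 3 lie past the limit stays open, so no order among the three compounds can be given. Also open, going by these compounds, is whether an amine or a carboxylic acid in place of these groups at this position would give a readable number.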